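The source may report more compounds than this note shows. Statements on the series, on what has been measured and on what is new or still open speak of the compounds shown alone.

In an ADME assay on HFF cells (Homo sapiens) for cytotoxicity, with a stated time of 8 days (on this read-out higher numbers stand for lower toxicity in this test and lower numbers for higher toxicity in this test), compound 1 `Nc1nc(OCC(F)(F)F)c2ncn(/C=C3/CC3(CO)CO)c2n1` gives only a limit, > 300000 nM. Compound 2 `CCCCCCCCOc1nc(N)nc2c1ncn2/C=C1/CC1(CO)CO` likewise reaches only a limit in this assay, > 300000 nM. Compound 3 `CN(C)c1nc(N)nc2c1ncn2/C=C1/CC1(CO)CO` too returns only a limit in this assay, > 300000 nM. The steps a step that the two limits leave unreadable from compound 1 to compound 2, a step that the two limits leave unreadable from compound 1 to compound 3 and a step that the two limits leave unreadable from compound 2 to compound 3 therefore cannot be sized, since (the limit of > 300000 nM in this assay, at which 3 of the 3 values shown sit). Compound 4 `CCCOc1nc(N)nc2c1ncn2/C=C1/CC1(CO)CO` differs from compound 1 by ethyl in place of trifluoromethyl on a saturated chain carbon bound to an oxygen on an aromatic ring. The nearest measured step, a step that the two limits leave unreadable from compound 1 to compound 2, also alters the chain on the same saturated carbon, yet its size is hidden by the two limits. No movement beyond the scatter is therefore expected in this assay, and compound 4 is expected to sit at the limit as well. The estimate for compound 4 in this assay is 300000 nM, between 150000 nM and 600000 nM. The expected step is accordingly a number no higher from compound 1 to compound 4 (the limit leaves the size open).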

Compound 4, half-maximal cytotoxic concentration: > 300000 nM
Compound 4 ended at the assay's limit; the forecaster's own chance of this, stated with the estimate: 85%; the middle value lies on the limit itself.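

In this assay, for the compounds shown here, compound 4 joins compound 1, compound 2 and compound 3 in giving only a limit, so no step among them can be read: the limit of > 300000 nM in this assay, at which 4 of the 4 values shown sit. The compounds shown leave open where each true half-maximal cytotoxic concentration lies and how the compounds rank.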